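The compounds below may be only part of what the source reports. "The series", "measured", "known", "first", "only" and "open" are said of these compounds alone.

Measured so far:
compound 1, `O=C(NNC(=O)C1CC1c1ccc(OC(F)(F)F)cc1)c1ccncc1`: 37000 nM
compound 2, `COc1ccc(C2CC2C(=O)NNc2nncc3ccccc23)cc1`: 83000 nM

In a functional assay on U-373MG ATCC cells (Homo sapiens) for inhibition, read by MTT assay, with a stated time of 72 h (on this read-out higher numbers stand for weaker inhibition and lower numbers for stronger inhibition), compound 2 gives the highest of the two numbers measured; compound 1 gives a lower number, and the gap between the two lies beyond the scatter. The two compounds differ in more than one place, so no single step can be read from them. Compound 3, `O=C(NNc1nncc2ccccc12)C1CC1c1ccc(OC(F)(F)F)cc1`, carries the change trifluoromethyl in place of methyl on an oxygen on an aromatic ring on the core of compound 2. Going by the values given here, no measured pair shows this change alone; the expected step of a 1.7-fold lower number from compound 2 to compound 3 (0.22 log units; within the scatter) is therefore small, toward a lower number, and may not pass beyond the scatter. Compound 3 is estimated at 50000 nM, within 20000 nM to 120000 nM.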

Compound 3, half-maximal inhibitory concentration: 85000 nM
For compound 3 the middle estimate is 1.7-fold (0.23 log units) below the measured one; the range from low to high includes it.
By their numbers in this assay, from the lowest: compound 1; then compounds 2 and 3 (each within the scatter of the next).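

In this assay, trifluoromethyl in place of methyl on the oxygen on the aromatic ring gives a step within the scatter (a 1.0-fold higher number from compound 2 to compound 3 (0.01 log units; within the scatter)). Going by these compounds alone, this is the first single-place comparison, and at this position it does not separate the methoxy and trifluoromethoxy compounds. No supporting data bear on this result.

Still open, as far as these compounds go, is whether an amine or a carboxylic acid in this place would move the number beyond the scatter. Also open is whether the same change behaves alike on the core of compound 1, since only its trifluoromethoxy form is shown.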